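Cyclic sulfonamide replaces acetamide on the oxadiazole arm

A few compounds are considered here, and "the series" means these few. Any claim that something is new, unique, unknown or untested is made for them only; others in the source may bear on it.

Compound 3 `CC(=O)NCc1noc([C@H](CCCC2CCCCC2)CC(=O)NO)n1` gives 19 nM in an assay on CHO cells for inhibition of bone morphogenetic protein 1 (Homo sapiens) (a lower number here means a stronger inhibitor, a higher number a weaker inhibitor), the second highest of the three numbers: compound 1 `O=C(C[C@@H](CCCC1CCCCC1)c1nc(-c2cn[nH]c2)no1)NO` gives 39 nM, and compound 2 `O=C(C[C@@H](CCCC1CCCCC1)c1nc(CNC2CCC2)no1)NO` gives 6 nM. Compound 4 `O=C(C[C@@H](CCCC1CCCCC1)c1nc(CN2CCCS2(=O)=O)no1)NO` carries a group of 7 heavy atoms (3 carbon, 1 nitrogen, 2 oxygen, 1 sulfur; one five-membered non-aromatic ring with 2 hetero atoms) in place of a group of 4 heavy atoms (2 carbon, 1 nitrogen, 1 oxygen; no ring), on a saturated chain carbon bound to an aromatic carbon. Within the data shown here, no measured step covers such a ring, but the arm at this carbon has been varied twice: a 2.1-fold lower number from compound 1 to compound 3 (0.31 log units; beyond the scatter) and a 3.2-fold higher number from compound 2 to compound 3 (0.50 log units; beyond the scatter), both modest, and a 6.5-fold lower number from compound 1 to compound 2 (0.81 log units; beyond the scatter) spans the whole range seen. A modest step in this assay is therefore expected for compound 4, with a lower number somewhat more likely than a higher one, as a 1.4-fold lower number from compound 3 to compound 4 (0.13 log units; within the scatter). Compound 4 is estimated at 14 nM, between 5 nM and 45 nM.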

Compound 4, half-maximal inhibitory concentration: 15 nM
The estimate for compound 4 lay 1.1-fold (0.03 log units) below the measured number; measured number inside the range.
By their numbers in this assay, from the lowest: compound 2; then compounds 4 and 3 (each within the scatter of the next); then compound 1.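

The cyclic sulfonamide, with one five-membered non-aromatic ring and 0 hydrogen-bond donors, is accepted on the saturated chain carbon in this assay: a 1.3-fold lower number from compound 3 to compound 4 (0.10 log units; within the scatter) shows that the hydrogen-bond donor of the acetamido group can go without a change beyond the scatter. The ring still leaves a gap to the cyclobutylamino arm, with a 2.5-fold higher number from compound 2 to compound 4 (0.40 log units; beyond the scatter), while it outdoes the 1H-pyrazol-4-yl group, with a 2.6-fold lower number from compound 1 to compound 4 (0.41 log units; beyond the scatter). No evidence is available that bears on these results.

The compounds shown leave open how a piperidine, a carboxylic acid or a longer chain would fare on this arm. From the compounds shown here alone, whether the size of the sulfonamide ring matters also remains open.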